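Same atoms, new link: from compound 3 to compound 4

The compounds below may be only part of what the source reports. "The series", "measured", "known", "first", "only" and "open" are said of these compounds alone.

Measured so far in a functional assay on B16-F0 cells (Mus musculus) for inhibition, read by CCK-8 assay, with a stated time of 48 h; on this read-out higher numbers stand for weaker inhibition and lower numbers for stronger inhibition
- compound 1 `COc1cc(-c2ccnc3cc(-c4ccc(C)c(C)c4)nn23)cc(OC)c1OC` gives 391 nM
- compound 2 `COc1cc(-c2ccnc3cc(-c4cccc(C#N)c4)nn23)cc(OC)c1OC` gives > 10000 nM (a limit of the assay, not a number)
- compound 3 `COc1cc(-c2ccnc3cc(-c4cn(C)c5ccccc45)nn23)cc(OC)c1OC` gives 185 nM

Compound 3 holds the lowest number here, and the nearest value belongs to compound 1, with a 2.1-fold lower number from compound 1 to compound 3 (0.33 log units; beyond the scatter) separating them. Compound 2 stands apart, since its entry is a limit and not a number.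

All three compounds share one core and differ only in the group on one aromatic carbon. Exchanging that group gave a 2.1-fold lower number from compound 1 to compound 3 (0.33 log units; beyond the scatter) in one case, but an at least 25-fold higher number from compound 1 to compound 2 (1.40 log units; beyond the scatter) and an at least 54-fold lower number from compound 2 to compound 3 (1.73 log units; beyond the scatter) in the others, so a change at this place can matter little or a great deal.

Compound 4 `COc1cc(-c2ccnc3cc(-c4ccc5ccn(C)c5c4)nn23)cc(OC)c1OC` is still unmeasured. Its change from compound 3 reads 1-methyl-1H-indol-6-yl in place of 1-methyl-1H-indol-3-yl on an aromatic carbon and keeps the same atoms, joined differently. Going by the values given here, no measured step shifts the attachment of one group in this way, so these steps are only a rough guide. Among the compounds with values here, with compound 3 at 185 nM as the lowest number so far, a moderate move towards a higher number, meaning weaker inhibition, is expected in this assay here. The expected change is a 2.7-fold higher number from compound 3 to compound 4 (0.43 log units; beyond the scatter) as an estimate. Compound 4 is estimated at 500 nM with an expected range of 120 nM to 4000 nM in this measurement.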

Compound 4, half-maximal inhibitory concentration: 657 nM
Estimate against measurement, compound 4: 1.3-fold (0.12 log units) below; low and high end bracket the measured number.
By their numbers in this assay, from the lowest: compound 3; then compounds 1 and 4 (each within the scatter of the next). At a limit, above all of these: compound 2.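

Moving the link of the same methylindole, with no atom added or lost, changes the result in this assay: a 3.6-fold higher number from compound 3 to compound 4 (0.55 log units; beyond the scatter). So at this position the point of attachment counts, not only which group is present. Compound 3's edge over compound 1 is also not shared by every methylindole, since the comparison with the 3,4-dimethylphenyl group gives a 1.7-fold higher number from compound 1 to compound 4 (0.23 log units; within the scatter), which does not separate the two. Compound 2 gives a limit and not a number, so the step to the 1-methyl-1H-indol-6-yl group, an at least 15-fold lower number from compound 2 to compound 4 (1.18 log units; beyond the scatter), has only a minimum size, and its true size cannot be read from this limit: the limit of > 10000 nM in this assay, at which 1 of the 4 values shown sits.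

Going by these compounds, only two attachment points of the methylindole appear here, so how another link such as 1-methyl-1H-indol-5-yl would read stays open. Also open, on these data alone, are whether the methyl on the indole nitrogen is needed and what a phenyl ring carrying an amine or a carboxylic acid would do at this place.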